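The compounds below may be only part of what the source reports. "The series", "measured", "known", "first", "only" and "open" are said of these compounds alone.

Measured compounds in a functional assay on A549 cells (Homo sapiens) for cytotoxicity, read by MTT assay, with a stated time of 24 h; a higher number here means a weaker inhibitor, a lower number a stronger inhibitor:
compound 1 `C=CC1=C(C(=O)NCCC)C(c2ccc(F)cc2)OC1` — compound 1 gives > 100000 nM, a limit of the assay.
compound 2 `C=CC1=C(C(=O)NC2CCCCC2)C(c2ccc(OC)c(OC)c2)OC1` — compound 2 gives > 100000 nM, a limit of the assay.
compound 3 `C=CC1=C(C(=O)NC2CCCCC2)C(c2ccc(OC)cc2)OC1` — compound 3 gives > 100000 nM, a limit of the assay.

Compound 1 thus stands at the limit, as does every measured member of the series: the limit of > 100000 nM in this assay, at which 3 of the 3 values shown sit. Among the compounds with values here, the single one-point step, a step that the two limits leave unreadable from compound 2 to compound 3, cannot be sized, since both of its ends are limits. Compound 4 `C=CC1=C(C(=O)Nc2ccccc2)C(c2ccc(F)cc2)OC1` differs from compound 1 by phenyl in place of propyl on an amide-type nitrogen. Within the data shown here, no measured step bears on this change, so no direction can be read for it in this assay; the series has so far given no number at all. Compound 4 is expected to remain at or near the limit. The estimated step is a number no higher from compound 1 to compound 4 (the limit leaves the size open). The estimate for compound 4 is 100000 nM, within 30000 nM to 300000 nM.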

Compound 4, half-maximal inhibitory concentration: > 100000 nM
Compound 4 gave a limit, no number; the forecaster's own chance of this, stated with the estimate: 80%; the middle value lies on the limit itself.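

No step can be read from compound 1 to compound 4, since both results are limits and not numbers: the limit of > 100000 nM in this assay, at which 4 of the 4 values shown sit.
In this assay the compounds shown leave open whether any change to the shared core gives a measurable value.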